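The compounds below may be only part of what the source reports. "The series", "measured", "known", "first", "only" and "open" are said of these compounds alone.

Compound 3 `Cc1ccc(-c2nc3c(c(C)nn3-c3ccccc3)c(-c3ccccc3O)c2C#N)cc1` stands highest of the three numbers in a physicochemical assay for solubility, read by spectrophotometry, in phosphate buffer, with a stated time of 18 h, at pH 7.4 (a higher number here means a more soluble compound, a lower number a less soluble compound), and gives 26000 nM. Compound 2 `CCc1ccc(-c2nc3c(c(C)nn3-c3ccccc3)c(-c3ccccc3C(=O)OC)c2C#N)cc1` gives 17000 nM, a value within the scatter of compound 3, while compound 1 `CCc1ccc(-c2nc3c(c(C)nn3-c3ccccc3)c(-c3ccccc3Br)c2C#N)cc1` gives 1500 nM, beyond it. Among the measured compounds shown here, the only measured step, an 11-fold higher number from compound 1 to compound 2 (1.05 log units; beyond the scatter), concerns a different aromatic carbon of the shared core, so it does not bear directly on the present change. Compound 4 `Cc1nn(-c2ccccc2)c2nc(-c3ccc([N+](=O)[O-])cc3)c(C#N)c(-c3ccccc3O)c12` differs from compound 3 by nitro in place of methyl on an aromatic carbon. For the measured compounds named here, no measured pair shows this exchange, so no step beyond the scatter is expected. For compound 4 the step of a 1.7-fold lower number from compound 3 to compound 4 (0.24 log units; within the scatter) is therefore estimated to be small. Compound 4 is expected to give about 15000 nM, with a range from 5000 nM to 45000 nM.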

Compound 4, solubility: 6000 nM
Beside the measured number, compound 4's estimate is 2.5-fold (0.40 log units) above it; the measured number falls inside the stated range.
By their numbers in this assay, from the lowest: compound 1; then compound 4; then compounds 2 and 3 (each within the scatter of the next).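

The exchange of 4-methylphenyl for 4-nitrophenyl gives a 4.3-fold lower number from compound 3 to compound 4 (0.64 log units; beyond the scatter) in this assay, so the number at this position does respond to the group on this aromatic carbon. Among the compounds shown here, this is the first reading at this position, since the earlier step concerned a different aromatic carbon of the shared core. Nothing measured here explains the step.

Going by these compounds, with one exchange at this position, it remains open whether an amine or a carboxylic acid on the same carbon would move the number in the same direction. On these data alone, whether the step would carry over to compounds with bromo or methoxycarbonyl at the other aromatic carbon also remains open.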